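Lengthening the Sulfonamide Aryl Substituent in a Thiazolyl Series

A few compounds are considered here, and "the series" means these few. Any claim that something is new, unique, unknown or untested is made for them only; others in the source may bear on it.

Compound 1 `CC(=O)Nc1nc(-c2cccc(NS(=O)(=O)c3cccc(Br)c3)c2)cs1`: 36%
Compound 2 `CC(=O)Nc1nc(-c2cccc(NS(=O)(=O)c3ccc(C#CCO)cc3)c2)cs1`: 48.8%

Two compounds share the core and differ only in the group on the sulfonyl-bearing ring. In a functional assay on A-375 cells (Homo sapiens) for antiproliferative activity, read by trypan blue exclusion, with a stated time of 48 h, tested at 10 uM (a lower number here means a stronger effect, a higher number a weaker effect of the compound at the concentration tested), compound 1 gives 36%, while compound 2 gives 48.8%; compound 2 thus stands as the highest of the two numbers, the gap to compound 1 lying beyond the scatter.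

Compound 3 `CCCCCC/C=C\c1ccc(S(=O)(=O)Nc2cccc(-c3csc(NC(C)=O)n3)c2)cc1` is the unmeasured partner of compound 2. It carries a longer chain in place of the hydroxypropynyl group: a group of 8 heavy atoms (8 carbon; no ring) in place of a group of 4 heavy atoms (3 carbon, 1 oxygen; no ring), on an aromatic carbon. Among the compounds with values here, no comparable step between measured compounds exists, so the expectation rests on the two numbers alone. A step of modest size toward a lower number is expected, a number 6.8 percentage points lower from compound 2 to compound 3 (within the scatter), though it may well lie within the scatter. For compound 3 the estimated value is 42%, with a range from 25% to 60%.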

Compound 3, a percentage reported as activity, at one concentration (the size of the read-out at that concentration, not a potency): <= 1%
Compound 3 gave a limit, no number (the forecaster's own chance of this, stated with the estimate: 0%); at least 41 percentage points between middle value and limit.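

In this assay, putting a group of 8 heavy atoms with one double bond in place of 3-hydroxyprop-1-yn-1-yl gives a number at least 47.8 percentage points lower from compound 2 to compound 3 (beyond the scatter) on this aromatic carbon. The earlier compounds shown here did not show that a change at this place alone, with the shared core kept, can move the read-out this far toward a stronger effect. From the compounds shown here alone, compound 3 gives <= 1% as a limit of the assay and not a number, and the full size of the step stays unknown: the limit of <= 1% in this assay, at which 1 of the 3 values shown sits.

This single pair cannot separate the part played by the length of the chain, its double bond and the loss of the hydroxyl. A saturated octyl chain, a shorter alkenyl chain or a chain ending in an amine would be needed to tell these apart.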